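Sulfonyl piperidines: cytotoxicity limits across the series

The source may hold more compounds than are shown below. What is called first, only, known or untested is meant among the compounds shown, and "the series" means these compounds.

Measured so far:
compound 1 `Cc1noc(C)c1S(=O)(=O)N1CCC(N2CCC(C)CC2)CC1`: > 10000 nM
compound 2 `Cc1c(C)c(S(=O)(=O)N2CCC(N3CCC(C)CC3)CC2)c(C)c2c1OC(C)(C)C2`: > 10000 nM
compound 3 `Cc1cc(C)c(S(=O)(=O)NCCN2CCC(C)CC2)c(C)c1`: > 5000 nM

In an ADME assay on HCT-116 cells (Homo sapiens) for cytotoxicity, read by CellTiter-Glo, with a stated time of 72 h (on this read-out higher numbers stand for weaker inhibition and lower numbers for stronger inhibition), compound 1 gives only a limit, > 10000 nM, and not a number. Compound 2 also sits at a limit, > 10000 nM. Compound 3 likewise returns a limit, > 5000 nM. Compound 1 therefore stands where all three measured compounds stand: at the top end of what this assay reports, with no separation among them. Among the compounds with values here, two of the three values rest at the limit of > 10000 nM in this assay, at which 2 of the 3 values shown sit, and one at the limit of > 5000 nM in this assay, at which 1 of the 3 values shown sits, so no ordering of the three can be drawn and no measured step exists between any pair.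

Compound 4 `CC1CCN(C2CCN(S(=O)(=O)c3cccc(Cl)c3)CC2)CC1` is the next compound to be tested. It differs from compound 1 by 3-chlorophenyl in place of 3,5-dimethyl-1,2-oxazol-4-yl on a sulfonyl sulfur. Within the data shown here, since no measured step is available, the expectation rests on the shared behaviour of compounds 1, 2 and 3. The step of a number no higher from compound 1 to compound 4 (the limit leaves the size open) is expected to be none beyond the scatter, in neither direction, because compound 1 sits at the limit of > 10000 nM in this assay, at which 2 of the 3 values shown sit, together with compound 2. Compound 4 is expected to return about 10000 nM, within 4000 nM to 30000 nM, most likely again as a limit rather than a number.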

Compound 4, half-maximal inhibitory concentration: > 5000 nM
Compound 4: a limit, no number; the forecaster's own chance of this, stated with the estimate: 75%; the middle value does not contradict the limit.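

Compound 1 and compound 4 both return limits and not numbers, and the step between them cannot be read; the change from 3,5-dimethyl-1,2-oxazol-4-yl to 3-chlorophenyl on the sulfonyl sulfur therefore has no readable size. The compounds shown leave open how any of them would rank if measured as a number.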